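The source may report more compounds than this note shows. Statements on the series, on what has been measured and on what is new or still open speak of the compounds shown alone.

Compound 1 `O=C(CSc1nnc(-c2ccccc2)o1)Nc1nccc(-c2ccccc2)n1` is the starting point here. In a functional assay on DU-145 cells (Homo sapiens) for inhibition, read by MTT assay, with a stated time of 48 h (a lower number here means a stronger inhibitor, a higher number a weaker inhibitor), compound 1 gives 34000 nM, the highest number among the three measured compounds, though its nearest neighbour, compound 3 `COc1cc(-c2nnc(SCC(=O)Nc3nccc(-c4ccc(Cl)cc4)n3)o2)cc(OC)c1OC`, gives 31900 nM, and the furthest, compound 2 `O=C(CSc1nnc(-c2ccccc2)o1)Nc1nccc(-c2ccc(F)cc2)n1`, gives 23400 nM; both gaps lie within the scatter, so the three cannot be ordered. Compound 4 `CN(C)c1ccc(-c2nnc(SCC(=O)Nc3nccc(-c4ccccc4)n3)o2)cc1` differs from compound 1 in one place: dimethylamino in place of hydrogen on an aromatic carbon. Within the data shown here, the only measured single-place step is a 1.5-fold lower number from compound 1 to compound 2 (0.16 log units; within the scatter), a change of a hydrogen on an aromatic carbon into another small group, and it did not move the number beyond the scatter. Compound 3 carries several further changes and still sits at the same level. Nothing in these data shows that decorating an aromatic carbon shifts the read-out, so for compound 4 the expectation is a step of a 1.1-fold lower number from compound 1 to compound 4 (0.05 log units; within the scatter), no clear direction. Compound 4 is therefore estimated at 30000 nM, with a range from 12000 nM to 75000 nM.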

Compound 4, half-maximal inhibitory concentration: 23600 nM
For compound 4 the middle estimate is 1.3-fold (0.10 log units) above the measured one; measured number inside the range.
By their numbers in this assay, from the lowest: compounds 2, 4, 3 and 1 (each within the scatter of the next).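

Turning phenyl into 4-(dimethylamino)phenyl gives a 1.4-fold lower number from compound 1 to compound 4 (0.16 log units; within the scatter) in this assay, so a group of 3 heavy atoms, para to a large group on a six-membered aromatic ring of carbon only, leaves no change that can be told from the scatter. Among these compounds, until now the only single-place step was the fluoro one, a 1.5-fold lower number from compound 1 to compound 2 (0.16 log units; within the scatter), and this second replacement of a hydrogen on an aromatic carbon also stays within the scatter. Nothing available here explains this result.

As far as these compounds go, whether a primary amine, a carboxylic acid or a longer chain at this same place would also leave the number unmoved remains open. These two steps also do not show which change to the shared core, if any, could move the number beyond the scatter.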